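Methoxy for methyl on the anilide of compound 2

The compounds below may be only part of what the source reports. "The series", "measured", "known", "first", "only" and "open" are said of these compounds alone.

The series shares one core. Compound 1 `COc1ccc2nc(C)cc(OCCNc3cc(C)cc(C)c3)c2c1` gives 31600 nM in a toxicity assay on HepG2 cells (Homo sapiens) for inhibition, read by CellTiter-Glo, with a stated time of 48 h; a lower number here means a stronger inhibitor, a higher number a weaker inhibitor. Compound 2 `COc1ccc2nc(C)cc(OCC(=O)Nc3cc(C)ccc3C)c2c1` reaches only a limit in this assay, reported as > 100000 nM; this is the limit (the limit of > 100000 nM in this assay, at which 1 of the 2 values shown sits). Compound 3 `COc1ccc2nc(C)cc(OCC(=O)Nc3cc(C)ccc3OC)c2c1` differs from compound 2 by methoxy in place of methyl on an aromatic carbon. Going by the values given here, no step between measured compounds is available, so the change is untested. The step that the limit leaves unreadable from compound 2 to compound 3 is expected to be none beyond the scatter, most likely ending again at the limit. Compound 3 is estimated at 120000 nM, with a range from 40000 nM to 400000 nM.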

Compound 3, half-maximal inhibitory concentration: > 100000 nM
Compound 3 ended at the assay's limit; the forecaster's own chance of this, stated with the estimate: 70%; the middle value is on the limit's open side.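

No step can be read from compound 2 to compound 3, because both end at a limit and not at a number: the limit of > 100000 nM in this assay, at which 2 of the 3 values shown sit. Going by these compounds, whether methoxy in place of methyl shifts the value in this assay stays open, in both size and direction.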